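A few compounds are considered here, and "the series" means these few. Any claim that something is new, unique, unknown or untested is made for them only; others in the source may bear on it.

Compound 1 `Nc1ccc2sc(NC(=S)NC(=O)c3ccc([N+](=O)[O-])cc3)nc2c1`: 63100 nM
Compound 2 `O=C(NC(=S)Nc1nc2cc(Br)ccc2s1)c1cccs1`: 46500 nM
Compound 3 `Nc1ccc2sc(NC(=S)NC(=O)c3cccs3)nc2c1`: 56100 nM

Of the compounds shown here, three have been measured in a functional assay on HeLa cells (Homo sapiens) for cytotoxicity, read by MTT assay, with a stated time of 24 h; a lower number here means a stronger inhibitor, a higher number a weaker inhibitor. In this assay compound 1 gives 63100 nM, compound 2 gives 46500 nM and compound 3 gives 56100 nM; all three numbers lie within the usual scatter of one another. Compounds 2 and 3 differ in one place, (bromo in place of amino on an aromatic carbon), and that change made a step of a 1.2-fold lower number from compound 3 to compound 2 (0.08 log units; within the scatter). The difference between the cores of compound 1 and compound 3 is not broken down here.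

Compound 4 `O=C(NC(=S)Nc1nc2cc(Br)ccc2s1)c1ccc([N+](=O)[O-])cc1` has not yet been measured in this assay. It is derived from compound 1 by bromo in place of amino on an aromatic carbon, the same change as that from compound 3 to compound 2, at the same place. Because the earlier step was a 1.2-fold lower number from compound 3 to compound 2 (0.08 log units; within the scatter), compound 4 is expected to sit close to compound 1, with a step of about a 1.1-fold lower number from compound 1 to compound 4 (0.06 log units; within the scatter), the expectation resting on that single pair alone. For compound 4 the estimate is 55000 nM, expected to fall between 25000 nM and 120000 nM.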

Compound 4, half-maximal inhibitory concentration: 56500 nM
For compound 4 the middle estimate is 1.0-fold (0.01 log units) below the measured one, and the stated range covers the measured number.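

In this assay, bromo in place of amino on an aromatic carbon made a step of a 1.1-fold lower number from compound 1 to compound 4 (0.05 log units; within the scatter). Set beside the earlier step on the other core, the change carries over with no difference that can be told apart: the same change on two cores in this assay, a 1.2-fold lower number (0.08 log units; within the scatter) from compound 3 to compound 2 and a 1.1-fold lower number (0.05 log units; within the scatter) from compound 1 to compound 4, 1.1-fold (0.03 log units) apart, within the scatter of two such steps. Going by these compounds alone, this shows only that the change leaves the number within the scatter on both of these cores; it does not show that amino and bromo differ in any real way in this assay, and two steps this small cannot show how the change would behave on a further core or whether it would ever give a step beyond the scatter.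

The compounds shown leave open whether another group at this place, such as chloro, methoxy or a carboxylic acid, would move the number beyond the scatter. They also leave open what an alkyl chain would do on the carbonyl, in place of the aromatic rings carried there by these four compounds.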